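Fluoro in Place of Hydrogen on the Aromatic Ring

A few compounds are considered here, and "the series" means these few. Any claim that something is new, unique, unknown or untested is made for them only; others in the source may bear on it.

Of the compounds shown here, three sharing one core have been measured in a functional assay on MCF7 cells (Homo sapiens) for inhibition, read by MTT assay, with a stated time of 48 h; on this read-out higher numbers stand for weaker inhibition and lower numbers for stronger inhibition. Compound 1 `CCOC(=O)c1c(N)sc(/N=C/c2ccccc2)c1C(=O)OCC` gives 6100 nM. Compound 2 `CCOC(=O)c1c(N)sc(/N=C/c2ccncc2)c1C(=O)OCC` gives 92200 nM, and compound 3 `CCOC(=O)c1c(N)sc(/N=C/c2ccc([N+](=O)[O-])cc2)c1C(=O)OCC` gives 1300 nM. Compound 1 therefore holds the second highest of the three numbers; its nearest neighbour is compound 3, reached by a 4.7-fold lower number from compound 1 to compound 3 (0.67 log units; beyond the scatter), while the furthest is compound 2, reached by a 15-fold higher number from compound 1 to compound 2 (1.18 log units; beyond the scatter).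

Compound 4 `CCOC(=O)c1c(N)sc(/N=C/c2ccc(F)cc2)c1C(=O)OCC` has not yet been measured. It differs from compound 1 in one place: fluoro in place of hydrogen on an aromatic carbon. Within the data shown here, of the measured steps, the one to compound 3 is the closest relative, as it also keeps the ring of compound 1 and merely adds a substituent to it, and it was a 4.7-fold lower number from compound 1 to compound 3 (0.67 log units; beyond the scatter) in size. The step to compound 2, a 15-fold higher number from compound 1 to compound 2 (1.18 log units; beyond the scatter), exchanged the ring itself and says less about a single substituent. The fluoro group enters as a single heavy atom with no donors or acceptors, so a step in this assay smaller than that to compound 3 is expected, downward if at all and possibly within the scatter. Compound 4 is thus estimated at 4500 nM, within the range 2000 nM to 12000 nM, which means an expected step of a 1.4-fold lower number from compound 1 to compound 4 (0.13 log units; within the scatter).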

Compound 4, half-maximal inhibitory concentration: 22500 nM
For compound 4 the middle estimate is 5.0-fold (0.70 log units) below the measured one; the measured number lies above the stated range.
By their numbers in this assay, from the lowest: compound 3; then compound 1; then compound 4; then compound 2.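

At this aromatic carbon, para to a large group, fluoro moved the number the opposite way to nitro: a 3.7-fold higher number from compound 1 to compound 4 (0.57 log units; beyond the scatter) in this assay, whereas nitro gave a 4.7-fold lower number from compound 1 to compound 3 (0.67 log units; beyond the scatter), so the direction of the step depends on which group enters and not merely on a group being added to the ring. Exchanging the two groups directly gives a 17-fold higher number from compound 3 to compound 4 (1.24 log units; beyond the scatter), and the fluoro compound still keeps its distance from the pyridine compound, with a 4.1-fold lower number from compound 2 to compound 4 (0.61 log units; beyond the scatter), which places it inside the span of the series and not at either end. Nothing measured alongside these numbers accounts for the upward fluoro step.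

With only hydrogen, fluoro and nitro at this carbon, three groups cannot show whether the numbers there follow any single trend, and a chlorine atom, a methoxy group, an amine or a nitrile at the same carbon would test this further. On these data alone, it also remains open whether fluoro would give a step of similar size and direction at another carbon of the ring, or on a core carrying different esters.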